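Aryl hydrazone series: notes ahead of compound 4

A few compounds are considered here, and "the series" means these few. Any claim that something is new, unique, unknown or untested is made for them only; others in the source may bear on it.

Measured so far:
- compound 1 `CN(C)CCn1cnnc1-c1cc(Oc2ccc(NC(=O)N/N=C/c3cccc(Br)c3)cc2F)ccn1`: 4230 nM
- compound 2 `CN(C)CCn1cnnc1-c1cc(Oc2ccc(NC(=O)N/N=C/c3ccccc3O[N+](=O)[O-])cc2F)ccn1`: 6860 nM
- compound 3 `COc1ccc(/C=N/NC(=O)Nc2ccc(Oc3ccnc(-c4nncn4CCN(C)C)c3)c(F)c2)c(OC)c1OC`: "not determined" (no result reported)

In an ADME assay on WI-38 cells (Homo sapiens) for cytotoxicity, read by MTT assay, with a stated time of 72 h (a higher number here means a weaker inhibitor, a lower number a stronger inhibitor), compound 1 gives 4230 nM and compound 2 gives 6860 nM. Going by the values given here, the only step between measured compounds, a 1.6-fold higher number from compound 1 to compound 2 (0.21 log units; within the scatter), exchanges one aryl group for another on the carbon double-bonded to nitrogen and does not move the number beyond the scatter. Among the compounds with values here, compound 3 stands on no number at all: in this assay compound 3 gives "not determined" (no result reported), so it offers no anchor of its own, and no step can be drawn from it.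

Compound 4 `CN(C)CCn1cnnc1-c1cc(Oc2ccc(NC(=O)N/N=C/c3c(Cl)cccc3Cl)cc2F)ccn1` differs from compound 3 as follows: 2,6-dichlorophenyl in place of 2,3,4-trimethoxyphenyl on a carbon with a double bond to nitrogen. Within the data shown here, no measured step shares this exact change. Among the measured compounds shown here, the one step that bears on it at all is a 1.6-fold higher number from compound 1 to compound 2 (0.21 log units; within the scatter), since it too varies the aryl group at the same carbon, and that step stayed within the scatter. On that basis no shift beyond the scatter is expected in this assay for an aryl exchange at this carbon, and compound 4 is expected near the band set by compounds 1 and 2. Compound 4 is estimated at 5500 nM, within 2200 nM to 14000 nM.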

Compound 4, half-maximal inhibitory concentration: 3320 nM
Compound 4: the middle estimate sits 1.7-fold (0.22 log units) above what was measured, within the range that was stated.
By their numbers in this assay, from the lowest: compounds 4, 1 and 2 (each within the scatter of the next, the first and the last beyond it).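

In this assay the aryl group on a carbon with a double bond to nitrogen now gives its first step beyond the scatter, a 2.1-fold lower number from compound 2 to compound 4 (0.32 log units; beyond the scatter) for 2,6-dichlorophenyl in place of 2-(nitrooxy)phenyl, so an aryl exchange at this carbon can move the number modestly. The same entering group in place of 3-bromophenyl gives a 1.3-fold lower number from compound 1 to compound 4 (0.11 log units; within the scatter) and so separates compound 1 and compound 4 by no more than the scatter, which makes the effect dependent on the group leaving. Nothing available accounts for the difference between these two steps.

Compound 3 still has no number, so the exchange of 2,3,4-trimethoxyphenyl for 2,6-dichlorophenyl cannot be read as a step. From the compounds shown here alone, how an aryl group carrying an amine or a carboxylic acid at this carbon would behave in this assay remains open.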